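Biaryl replacement for the isopropoxy ether on the amide core

The source may report more compounds than this note shows. Statements on the series, on what has been measured and on what is new or still open speak of the compounds shown alone.

Compound 1 `CC(C)Oc1ccc(S(C)(=O)=O)cc1C(=O)N1Cc2cc(C(F)(F)F)cnc2C1` gives 70 nM in an assay on CHO cells for inhibition of sodium- and chloride-dependent glycine transporter 1 (Homo sapiens), read by scintillation counting (on this read-out higher numbers stand for an effect only at larger amounts of compound and lower numbers for an effect already at smaller amounts), the higher of the two numbers in hand; compound 2 `CC(C)Oc1ccc(S(C)(=O)=O)cc1C(=O)N1Cc2ccc(C3CCOCC3)cc2C1` gives 28 nM in this assay, a difference beyond the usual scatter. Compound 3 `CS(=O)(=O)c1ccc(-c2ccc(F)c(F)c2)c(C(=O)N2Cc3cc(C(F)(F)F)cnc3C2)c1` carries 3,4-difluorophenyl in place of isopropoxy on an aromatic carbon, placed para to a methylsulfonyl group. Going by the values given here, no measured pair covers such a swap, so its effect is open. A modest step is expected, more likely toward a lower number than a higher one, yet within range of no change. Compound 3 is estimated at 45 nM, between 12 nM and 180 nM, which from compound 1 means an expected step of a 1.6-fold lower number from compound 1 to compound 3 (0.19 log units; within the scatter).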

Compound 3, half-maximal effective concentration in the sodium- and chloride-dependent glycine transporter 1 assay: 30 nM
For compound 3 the middle estimate is 1.5-fold (0.18 log units) above the measured one; low and high end bracket the measured number.
By their numbers in the sodium- and chloride-dependent glycine transporter 1 assay, from the lowest: compounds 2 and 3 (each within the scatter of the next); then compound 1.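

On the shared core, the aromatic carbon para to a methylsulfonyl group tolerates an aromatic ring in place of isopropoxy: in the sodium- and chloride-dependent glycine transporter 1 assay, the swap to 3,4-difluorophenyl brings a 2.3-fold lower number from compound 1 to compound 3 (0.37 log units; beyond the scatter). The ether oxygen of isopropoxy is therefore not required at this position to retain activity on this read-out. In a physicochemical assay for solubility (on this read-out lower numbers stand for lower solubility and higher numbers for higher solubility), compound 1 gives 114 ug/mL and compound 3 gives 42 ug/mL. The same change carries a cost in the physicochemical assay: the measured solubility of compound 1, 114 ug/mL, and of compound 3, 42 ug/mL, a 2.7-fold lower number (0.43 log units; beyond the scatter)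

Going by these compounds, it remains open whether the lower number comes from the ring or from its two fluorines, which an unsubstituted phenyl would separate. Also open, on these data alone, is whether a pyridine ring here would hold the result in the sodium- and chloride-dependent glycine transporter 1 assay while giving higher numbers in the physicochemical assay.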